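Replacing an oxygen-linked ring group with isopropylsulfanyl

The source may report more compounds than this note shows. Statements on the series, on what has been measured and on what is new or still open speak of the compounds shown alone.

Of the compounds shown here, two of a shared core have been measured in a functional assay on isolated protein for inhibition of Glucose-dependent insulinotropic receptor (Rattus norvegicus), read by HTRF and cAMP accumulation; on this read-out lower numbers stand for smaller maximal responses and higher numbers for larger maximal responses. Compound 1 `Cc1nc(S(C)(=O)=O)ccc1Oc1ncnc(OC2CCN(C(=O)OC(C)(C)C(F)(F)F)CC2)c1F` gives 79% in this assay. Compound 2 `Cc1nc(S(C)(=O)=O)ccc1Oc1ncnc(OC2CCN(C(=O)OC3(C(F)(F)F)COC3)CC2)c1F` gives 84% in this assay. Where compound 2 stands is told by the only measured step, a number 5 percentage points higher from compound 1 to compound 2 (within the scatter): the gap to compound 1, its only neighbour, is within the scatter, so the two numbers are not to be ordered.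

Compound 3 `Cc1nc(S(C)(=O)=O)ccc1Oc1ncnc(OC2CCN(C(=O)SC(C)C)CC2)c1F` has not yet been measured. It differs from compound 2 by isopropylsulfanyl in place of (3-(trifluoromethyl)oxetan-3-yl)oxy on a carbonyl carbon. Among the compounds with values here, no measured step covers an exchange of this kind. Within the data shown here, the single step on record, a number 5 percentage points higher from compound 1 to compound 2 (within the scatter), only exchanged the group on an oxygen next to a carbonyl group and stayed within the scatter; it gives no direction for removing that oxygen together with its four-membered ring and placing isopropylsulfanyl on the carbonyl carbon. With so little to go on, no step beyond the scatter is expected, and the step of a number 4 percentage points lower from compound 2 to compound 3 (within the scatter) is the estimate. Compound 3 is therefore expected to give about 80% in this assay, with a range from 62% to 95%.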

Compound 3, largest response reached (reported as efficacy), in percent of the reference or control that the assay uses: 81%
For compound 3 the middle estimate is 1 percentage points below the measured one, within the range that was stated.
By their numbers in this assay, from the lowest: compounds 1, 3 and 2 (each within the scatter of the next).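

In this assay, this carbonyl carbon now carries a sulfur-linked group instead of an oxygen-linked one, and the result is a number 3 percentage points lower from compound 2 to compound 3 (within the scatter) and a number 2 percentage points higher from compound 1 to compound 3 (within the scatter) when set against the other oxygen-linked group. The exchange against compound 2 takes away the oxetane ring and all three fluorines, and the 9 heavy atoms of (3-(trifluoromethyl)oxetan-3-yl)oxy give way to the 4 of isopropylsulfanyl, yet the maximal response does not move beyond the scatter. No measurement on record offers an explanation for this result.

The compounds shown leave open what the sulfur itself contributes, since the exchange alters the linking atom and the group behind it at once, and isopropoxy on the same carbonyl carbon would separate those two parts. On these data alone, as no group here has moved the number beyond the scatter, the limits of this position also remain open, and a nitrogen-linked group such as dimethylamino or a plain methyl group on that carbon would test them.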